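Moving the chlorine on compound 2's aryl carbonyl

The source may report more compounds than this note shows. Statements on the series, on what has been measured and on what is new or still open speak of the compounds shown alone.

Measured so far:
compound 1 `COc1ccc(C(=O)NCc2ccc(CNS(=O)(=O)c3ccccc3)cc2)cc1`: 1000 nM
compound 2 `O=C(NCc1ccc(CNS(=O)(=O)c2ccccc2)cc1)c1cccc(Cl)c1`: 1000 nM

In an assay on MDA-MB-231 cells for binding affinity to C-X-C chemokine receptor type 4 (Homo sapiens), read by immunofluorescence and microscopy, with stated times of 10 min and 30 min (on this read-out higher numbers stand for an effect only at larger amounts of compound and lower numbers for an effect already at smaller amounts), compound 2 gives 1000 nM, and it stands level with compound 1 at the digits shown. Going by the values given here, the one measured step, no change at the digits printed from compound 1 to compound 2 (within the scatter), exchanged 3-chlorophenyl for 4-methoxyphenyl on a carbonyl carbon and produced no change within the scatter. Compound 3 `O=C(NCc1ccc(CNS(=O)(=O)c2ccccc2)cc1)c1ccccc1Cl` has not yet been measured; it differs from compound 2 by 2-chlorophenyl in place of 3-chlorophenyl on a carbonyl carbon. Among the compounds with values here, the single measured step concerns a different change on the same carbonyl carbon, so it gives no direct guide to moving the chlorine, though it shows that this part of the shared core tolerated one alteration without a shift in this assay. On that basis the account expects no step beyond the scatter, no change at the digits printed from compound 2 to compound 3 (within the scatter). Compound 3 is therefore estimated at 1000 nM in this assay, with a range from 400 nM to 3000 nM.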

Compound 3, effective concentration (reported as EC, without a stated level of effect): 10 nM
Beside the measured number, compound 3's estimate is 100-fold (2.00 log units) above it; measured number below the stated range.
By their numbers in this assay, from the lowest: compound 3; then compounds 1 and 2 (each within the scatter of the next).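

In this assay, going by these compounds alone, the place of the chlorine on the ring attached to the carbonyl carbon proves decisive, which the earlier compounds did not reveal: with the same atoms joined differently, 2-chlorophenyl in place of 3-chlorophenyl gives a 100-fold lower number from compound 2 to compound 3 (2.00 log units; beyond the scatter). The exchange of 4-methoxyphenyl for 2-chlorophenyl gives a 100-fold lower number from compound 1 to compound 3 (2.00 log units; beyond the scatter), so the group on this carbonyl carbon is not as indifferent as the step between the first two compounds alone had suggested. Nothing measured here accounts for this step.

From the compounds shown here alone, it remains open whether the lower number depends on chlorine itself, as bromine or a methyl group in place of that chlorine in the 2-chlorophenyl would show. Also open, going by these compounds, is whether the step would persist with a change elsewhere on the shared core.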